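Cytotoxicity in the thienopyrimidine ether series: acetamido for bromo

The compounds below may be only part of what the source reports. "The series", "measured", "known", "first", "only" and "open" are said of these compounds alone.

Measured so far:
compound 1 `Cc1cc(C#N)cc(C)c1Oc1nc(NC2CCC(NS(=O)(=O)c3cccc(C(F)(F)F)c3)CC2)nc2ccsc12` — 6680 nM
compound 2 `Cc1cc(C#N)cc(C)c1Oc1nc(NC2CCC(NC(=O)c3ccc(Br)cc3)CC2)nc2ccsc12` — 2850 nM
compound 3 `Cc1cc(C#N)cc(C)c1Oc1nc(NC2CCC(NS(=O)(=O)c3ccc(Br)cc3)CC2)nc2ccsc12` — 5860 nM

In an ADME assay on MT4 cells (Homo sapiens) for cytotoxicity, read by MTT assay, with a stated time of 5 days (on this read-out higher numbers stand for lower toxicity in this test and lower numbers for higher toxicity in this test), compound 3 stands second highest of the three numbers. Its nearest neighbour is compound 1, where the step of a 1.1-fold lower number from compound 1 to compound 3 (0.06 log units; within the scatter) lies within the scatter. The furthest is compound 2, where the step of a 2.1-fold higher number from compound 2 to compound 3 (0.31 log units; beyond the scatter) is modest but beyond the scatter.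

Compound 4 `CC(=O)Nc1ccc(S(=O)(=O)NC2CCC(Nc3nc(Oc4c(C)cc(C#N)cc4C)c4sccc4n3)CC2)cc1` is not yet measured. It differs from compound 3 in one place: acetamido in place of bromo on an aromatic carbon, on an aromatic carbon of a six-membered aromatic ring of carbon only, para to a large group. Within the data shown here, of the two measured steps, only the one from compound 1 to compound 3 concerns a change on the aryl ring of the sulfonyl group, and it stayed within the scatter. The step from compound 2 to compound 3 concerns the sulfonyl against the carbonyl and does not bear on the present change. Among the measured compounds shown here, no measured compound carries an acetamido group, so the expectation rests on one step alone.

Compound 4 is therefore expected to give a number close to that of compound 3, with the step of a 1.1-fold higher number from compound 3 to compound 4 (0.05 log units; within the scatter) estimated as within the scatter. The estimate for compound 4 in this assay is 6500 nM, with a range from 3000 nM to 14000 nM.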

Compound 4, half-maximal cytotoxic concentration: 3730 nM
The estimate for compound 4 lay 1.7-fold (0.24 log units) above the measured number, within the range that was stated.
By their numbers in this assay, from the lowest: compounds 2, 4, 3 and 1 (each within the scatter of the next, the first and the last beyond it).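

In this assay, the step of a 1.6-fold lower number from compound 3 to compound 4 (0.20 log units; within the scatter) shows that this position, an aromatic carbon para to a large group, accepts acetamido in place of bromo without a change beyond the scatter, even though acetamido brings 4 heavy atoms, a hydrogen-bond donor and a hydrogen-bond acceptor where bromo brings 1 heavy atom and neither. The step of a 1.8-fold lower number from compound 1 to compound 4 (0.25 log units; within the scatter) also stays within the scatter, so 3-(trifluoromethyl)phenyl, 4-bromophenyl and 4-acetamidophenyl on the sulfonyl sulfur cannot be told apart on this read-out. Nothing available bears on why these aryl groups give such similar numbers.

As far as these compounds go, whether an amine or a carboxylic acid on the same aromatic carbon would give a step beyond the scatter remains open, and so does whether a longer chain than acetamido would do so. From the compounds shown here alone, it is also open whether 4-acetamidophenyl on the carbonyl linkage of compound 2 would keep the sulfonyl-to-carbonyl difference seen with 4-bromophenyl, since that comparison exists for the bromo pair alone.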